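Carbamoyl for Methoxymethoxy: Stepping from Compound 1 to Compound 3

The compounds below may be only part of what the source reports. "The series", "measured", "known", "first", "only" and "open" are said of these compounds alone.

Compound 1 `COCOc1cc(=O)oc2cc(OCc3cccc(Cl)c3)ccc12` gives 100 nM in an assay on isolated protein (strain Sprague-Dawley) for inhibition of Amine oxidase [flavin-containing] B (Rattus norvegicus), read by spectrophotometry, with a stated time of 5 min; a lower number here means a stronger inhibitor, a higher number a weaker inhibitor.
Compound 2 `CCNc1cc(=O)oc2cc(OCc3cccc(Cl)c3)ccc12` gives 28.2 nM in this assay.

Among the measured compounds shown here, compound 1 stands at the higher of the two numbers; its nearest neighbour is compound 2, reached by a 3.5-fold lower number from compound 1 to compound 2 (0.55 log units; beyond the scatter), the only measured step, with ethylamino in place of methoxymethoxy on an aromatic carbon. Compound 3 `NC(=O)c1cc(=O)oc2cc(OCc3cccc(Cl)c3)ccc12` is not yet measured. It differs from compound 1 in carbamoyl in place of methoxymethoxy on an aromatic carbon. For the measured compounds named here, the one measured step bears only loosely on this change: it shows that swapping methoxymethoxy on that aromatic carbon for a small group gave a modest lower number, but carbamoyl is neither ethylamino nor methoxymethoxy, and no measured pair shows its effect. A step of at most modest size in this assay is therefore expected, leaning toward a lower number, though a step within the scatter is equally plausible. Compound 3 is expected to give 80 nM in this assay, within a range from 20 nM to 320 nM. That estimate corresponds to an expected step of a 1.3-fold lower number from compound 1 to compound 3 (0.10 log units; within the scatter).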

Compound 3, half-maximal inhibitory concentration: 234 nM
Compound 3: the middle estimate sits 2.9-fold (0.47 log units) below what was measured; the range from low to high includes it.
By their numbers in this assay, from the lowest: compound 2; then compound 1; then compound 3.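

In this assay the earlier pair had shown only a change toward a lower number at this aromatic carbon opposite the ring oxygen, whereas carbamoyl gives a 2.3-fold higher number from compound 1 to compound 3 (0.37 log units; beyond the scatter) and so moves the other way. Replacements of methoxymethoxy here therefore do not all go in one direction, and the two replacing groups stand well apart, with an 8.3-fold higher number from compound 2 to compound 3 (0.92 log units; beyond the scatter) marking the widest gap among the three compounds. Nothing at hand explains this difference in direction.

The compounds shown leave open how a carboxylic acid or a methyl ester on this carbon would compare with carbamoyl. They also leave open whether a simple amine or a longer alkylamino chain would keep the lower number seen with ethylamino.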